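A Bromine in Place of a Methoxy Group

The compounds below may be only part of what the source reports. "The series", "measured", "known", "first", "only" and "open" are said of these compounds alone.

Of the compounds shown here, three sharing one core have been measured in a functional assay on HT-29 cells (Homo sapiens) for antiproliferative activity, read by CellTiter-Glo, with a stated time of 72 h; a lower number here means a stronger inhibitor, a higher number a weaker inhibitor. Compound 1 `CC1CCN(C2CCN(S(=O)(=O)c3cccc4ccccc34)CC2)CC1` gives 0.34 nM in this assay. Compound 2 `CC1CCN(C2CCN(S(=O)(=O)c3cccc(Br)c3)CC2)CC1` gives 1.2 nM. Compound 3 `COc1ccc(OC)c(S(=O)(=O)N2CCC(N3CCC(C)CC3)CC2)c1` gives 4 nM, the highest of the three numbers; its gap to compound 2 is beyond the scatter, and its gap to compound 1 is larger still. No pair among these three differs in a single place, so no isolated step can be read from the measured set.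

Compound 4 `COc1ccc(Br)cc1S(=O)(=O)N1CCC(N2CCC(C)CC2)CC1` is the next compound to be measured in this assay. Relative to compound 3 the change is bromo in place of methoxy on an aromatic carbon. Among the measured compounds shown here, the data hold no step of exactly this kind, so the expected size of the change rests only on what the three measured compounds show. Compound 2 also carries a bromo group on its aromatic ring and gives 1.2 nM, a lower number than compound 3, which suggests a downward direction for compound 4. The expected step from compound 3 to compound 4 is therefore a 2.0-fold lower number from compound 3 to compound 4 (0.30 log units; within the scatter), a modest move toward a stronger inhibitor that may not clear the scatter. Compound 4 is estimated to give 2 nM in this assay, with a range from 0.6 nM to 6 nM.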

Compound 4, half-maximal inhibitory concentration: 2 nM
Compound 4: middle estimate and measured number agree at the digits printed, within the range that was stated.
By their numbers in this assay, from the lowest: compound 1; then compounds 2, 4 and 3 (each within the scatter of the next, the first and the last beyond it).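

In this assay, among the compounds shown here, the exchange of methoxy for bromo on this aromatic carbon, meta to a large group and para to a methoxy group, gives the first isolated step: a 2.0-fold lower number from compound 3 to compound 4 (0.30 log units; within the scatter). At this place the two groups therefore cannot be told apart, even though the exchange swaps two heavy atoms for one and removes a hydrogen-bond acceptor, and the second new step points the same way for the other methoxy group on the ring, since methoxy in place of hydrogen gives a 1.7-fold higher number from compound 2 to compound 4 (0.22 log units; within the scatter). Neither step clears the scatter, and nothing measured here offers an explanation for either of them.

The compounds shown leave open whether a different group at this place, such as chloro, a nitrile, an amine or a carboxylic acid, would give a step beyond the scatter, since bromo and methoxy are the only two compared there. They also leave open what hydrogen at this place would give while the methoxy group para to it stays, a comparison that would isolate the contribution of the bromo group itself.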